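The source may hold more compounds than are shown below. What is called first, only, known or untested is meant among the compounds shown, and "the series" means these compounds.

Among the measured compounds shown here, in a physicochemical assay for pharmacokinetics, at pH 8 (a higher number here means that the compound lasts longer, a lower number that the compound disappears faster), compound 1 `O=C(Sc1cccnc1C(=O)O)c1ccccc1` gives 60.1 h, the middle of the three numbers so far. Compound 3 `COc1ccc(C(=O)Sc2cccnc2C(=O)O)cc1` stands higher at 182 h, and compound 2 `O=C(Sc1cccnc1C(=O)O)c1cccc(C(F)(F)F)c1` stands lower at 10 h.

The next molecule, compound 4 `CC(C)(C)C(=O)Sc1cccnc1C(=O)O`, carries tert-butyl in place of phenyl on a carbonyl carbon.

For the measured compounds named here, two measured steps bear on this change, though only indirectly. Trifluoromethyl in place of hydrogen on an aromatic carbon gave a 6.0-fold lower number from compound 1 to compound 2 (0.78 log units; beyond the scatter), while methoxy in place of hydrogen on an aromatic carbon gave a 3.0-fold higher number from compound 1 to compound 3 (0.48 log units; beyond the scatter). Both steps are modest but beyond the scatter, and they run in opposite directions. Going by the values given here, each one only decorates the phenyl, whereas compound 4 loses that phenyl entirely, so the data offer no direct precedent. These steps therefore serve mainly as a guide to size. A step at least as large as these is expected, and its direction cannot be read from the three measured compounds. A rise is judged somewhat more likely than a fall, but this is a judgement only, and the range is kept wide to allow for a fall.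

The expected move is a 3.3-fold higher number from compound 1 to compound 4 (0.52 log units; beyond the scatter).

For compound 4, the estimated half-life is 200 h, within an expected range of 40 h to 1000 h.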

Compound 4, half-life: 115 h
For compound 4 the middle estimate is 1.7-fold (0.24 log units) above the measured one; measured number inside the range.
By their numbers in this assay, from the lowest: compound 2; then compounds 1, 4 and 3 (each within the scatter of the next, the first and the last beyond it).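

In this assay, tert-butyl in place of phenyl on a carbonyl carbon gives a 1.9-fold higher number from compound 1 to compound 4 (0.28 log units; within the scatter) and so leaves the half-life within the usual scatter, even though the whole aromatic ring is gone. The earlier steps shown here only decorated the phenyl, and they moved the number beyond the scatter in opposite directions, with a 6.0-fold lower number from compound 1 to compound 2 (0.78 log units; beyond the scatter) for trifluoromethyl and a 3.0-fold higher number from compound 1 to compound 3 (0.48 log units; beyond the scatter) for methoxy. This position therefore accepts a group with no ring and fewer heavy atoms without a change that can be told from the scatter, while the two substituted phenyl compounds show that the number can still respond to changes made on that ring. Nothing measured here accounts for this result.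

The compounds shown leave open whether a straight butyl chain, or a group carrying an amine or a carboxylic acid, would also stay within the scatter of compound 1 on this carbonyl carbon. They also leave open how a saturated ring such as cyclohexyl would behave in place of phenyl.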